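The source may hold more compounds than are shown below. What is called first, only, known or untested is meant among the compounds shown, and "the series" means these compounds.

Series notes, amine-linked esters on a shared core. In a functional assay on the whole organism (strain Wistar albino) for inhibition, with Rattus norvegicus as the target, read by paw edema, with stated times of 30 min and 2 h, at a dose of 20 mg/kg by the oral route (on this read-out lower numbers stand for less inhibition and higher numbers for more inhibition at the one dose given (going by the name of the read-out)), compound 1 `COc1ccc(NCC(=O)Oc2ccc3c(C)cc(=O)oc3c2)cc1` gives 33.3%. Compound 2 `Cc1cc(=O)oc2cc(OC(=O)CNc3ccccc3Cl)ccc12` gives 11.5% in this assay, and compound 3 `Cc1cc(=O)oc2cc(OC(=O)CNc3ccc(Cl)cc3)ccc12` gives 23% there. Compound 3 thus stands second highest of the three numbers: the step of a number 10.3 percentage points lower from compound 1 to compound 3 (beyond the scatter) sets it under compound 1, while the step of a number 11.5 percentage points higher from compound 2 to compound 3 (beyond the scatter) sets it over compound 2, both beyond the scatter but modest.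

Compound 4 `Cc1cc(=O)oc2cc(OC(=O)CNc3nccs3)ccc12` differs from compound 3 by 1,3-thiazol-2-yl in place of 4-chlorophenyl on an amine nitrogen. Within the data shown here, the steps that bear on it are those that alter the group on the amine nitrogen: a number 21.8 percentage points lower from compound 1 to compound 2 (beyond the scatter) and a number 11.5 percentage points higher from compound 2 to compound 3 (beyond the scatter), together with a number 10.3 percentage points lower from compound 1 to compound 3 (beyond the scatter). All three are modest, and none swaps the six-membered ring for a five-membered ring with two hetero atoms, so the direction here is open. A modest shift in either direction, or none beyond the scatter, is expected in this assay. Compound 4 is estimated at 22%, in a range from 8% to 36%. This estimate means an expected step of a number 1 percentage points lower from compound 3 to compound 4 (within the scatter), within the scatter.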

Compound 4, a percentage reported as inhibition, in the whole organism at one dose (the size of the read-out at that dose, not a potency): 37.1%
Compound 4: the middle estimate sits 15.1 percentage points below what was measured; the whole stated range lies below it.
By their numbers in this assay, from the lowest: compound 2; then compound 3; then compounds 1 and 4 (each within the scatter of the next).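

Five-membered aromatic rings with 2 hetero atoms are now shown to be accepted on the amine nitrogen in this assay: 1,3-thiazol-2-yl in place of 4-chlorophenyl gives a number 14.1 percentage points higher from compound 3 to compound 4 (beyond the scatter), and in place of 2-chlorophenyl it gives a number 25.6 percentage points higher from compound 2 to compound 4 (beyond the scatter). In place of 4-methoxyphenyl it gives a number 3.8 percentage points higher from compound 1 to compound 4 (within the scatter), so this pair cannot be told apart, and a six-membered aromatic ring of carbon only is not required for a value at this level. No measured data on these compounds account for the gain over the two chlorophenyl compounds.

Still open, going by these compounds, is whether the ring size or the hetero atoms carry this difference. Pyridin-2-yl and 1,3-oxazol-2-yl on the same amine nitrogen, with unsubstituted phenyl as a reference, would help separate these.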